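The compounds below may be only part of what the source reports. "The series", "measured", "known", "first", "only" and "open" are said of these compounds alone.

Compound 1 `CC(C)[C@@H](NC(=O)/C=C/c1ccncc1-c1ccc2ccccc2c1)C(=O)O` — in an assay on a protein complex for inhibition of CDK8/Cyclin C (Homo sapiens), with a stated time of 1 h (on this read-out higher numbers stand for weaker inhibition and lower numbers for stronger inhibition), compound 1 has "not determined" (no result reported).
Compound 2 `CNC(=O)/C=C/c1ccncc1-c1ccc2ccccc2c1` — compound 2 gives 12.4 nM.
Compound 3 `CN1CCN(C(=O)/C=C/c2ccncc2-c2ccc3ccccc3c2)CC1` — compound 3 gives 43.6 nM.
Compound 4 `CN(C)C(=O)/C=C/c1ccncc1-c1ccc2ccccc2c1` — not yet measured.

Compound 3 stands at the higher of the two numbers that exist, with compound 2 at the lower one; the step of a 3.5-fold higher number from compound 2 to compound 3 (0.55 log units; beyond the scatter), from methylamino to 4-methylpiperazin-1-yl on a carbonyl carbon, raised the number beyond the usual scatter. Compound 4 changes the same spot: dimethylamino in place of 4-methylpiperazin-1-yl on a carbonyl carbon. Going by the values given here, only that one measured step bears on this change, and it showed a small amine on the carbonyl carbon giving a lower number than the 4-methylpiperazin-1-yl. Compound 4 returns to a small amine, so a modest fall is expected, a 2.2-fold lower number from compound 3 to compound 4 (0.34 log units; beyond the scatter). The estimate for compound 4 is 20 nM, within 8 nM to 60 nM.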

Compound 4, half-maximal inhibitory concentration: 30.1 nM
Compound 4: the middle estimate sits 1.5-fold (0.18 log units) below what was measured; measured number inside the range.
By their numbers in this assay, from the lowest: compound 2; then compounds 4 and 3 (each within the scatter of the next).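

Replacing 4-methylpiperazin-1-yl with dimethylamino gives a 1.4-fold lower number from compound 3 to compound 4 (0.16 log units; within the scatter), so removing the ring leaves the number within the scatter. Methyl in place of hydrogen on the amide-type nitrogen matters more, with a 2.4-fold higher number from compound 2 to compound 4 (0.39 log units; beyond the scatter); among these three compounds, the clear gap separates compound 2, which keeps the amide hydrogen, from compounds 3 and 4, which lack it. Nothing measured here explains this gap.

On these data alone, it remains open whether ethylamino, with its longer chain and retained amide hydrogen, would keep the lower number. The effect of a larger amine such as cyclohexylamino is also unknown.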